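Compound 1 and one added methoxy

A few compounds are considered here, and "the series" means these few. Any claim that something is new, unique, unknown or untested is made for them only; others in the source may bear on it.

compound 1 `COc1ccc(-c2c(C)nc3c(N4CC[C@@H](NC(C)=O)C4)cc(C)nn23)cc1OC`: > 95%
compound 2 `COc1ccc(-c2scc3c(N4CC[C@@H](NC(C)=O)C4)nc(C)nc23)cc1OC`: > 95%
compound 3 `CC(=O)N[C@@H]1CCN(c2cc(C)nn3c(-c4ccccc4)c(C)nc23)C1`: > 95%

In an ADME assay on microsomes from liver (Homo sapiens) for metabolic stability, read by LC-MS, with NADPH named in the record, with a stated time of 60 min, tested at 1 uM, in the absence of a further agent (a lower number here means that less of the compound is left, a higher number that more of the compound is left), compound 1 gives > 95% and this is a limit of the assay, not a number. Compound 2 and compound 3 give no number either, and the measured set shows the limit of > 95% in this assay, at which 3 of the 3 values shown sit, throughout.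

Compound 4 `COc1cc(-c2c(C)nc3c(N4CC[C@@H](NC(C)=O)C4)cc(C)nn23)cc(OC)c1OC` is compound 1 with methoxy in place of hydrogen on an aromatic carbon. Among the measured compounds shown here, only the step that the two limits leave unreadable from compound 1 to compound 3 bears on this change: it also concerns methoxy groups on the same aromatic ring, and both its ends are limits, so no size can be taken from it. No step beyond the scatter is therefore expected in this assay from the added methoxy. The estimated step is a number no higher from compound 1 to compound 4 (the limit leaves the size open) and it is expected to stay within the scatter, if anything as a slight fall from the limit. Compound 4 is estimated at 95% with an expected range from 82% to 100% around it.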

Compound 4, percent of the compound remaining: > 95%
Compound 4: only a limit was reported; the forecaster's own chance of this, stated with the estimate: 60%; the middle value lies on the limit itself.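

In this assay compound 4 gives > 95% and this is a limit of the assay, not a number. Compound 1 also stands at a limit, so no step can be read between compound 1 and compound 4. The compounds shown leave open how far the added methoxy shifts the percent remaining, since all of them sit at one value: the limit of > 95% in this assay, at which 4 of the 4 values shown sit.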